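The source may hold more compounds than are shown below. What is called first, only, known or untested is meant among the compounds shown, and "the series" means these compounds.

Working notes on the series. Compound 1 `O=C(O)c1csc([C@H]2CC[C@@H]3[C@@H](/C=C/CCCOc4ccccc4)[C@H](O)C[C@@H]3O2)n1` gives 8500 nM in a functional assay on Chem1 cells for agonist activity at prostaglandin F2-alpha receptor (Homo sapiens), read by fluorescence and calcium flux; on this read-out higher numbers stand for an effect only at larger amounts of compound and lower numbers for an effect already at smaller amounts. Compound 2 `O=C(O)c1csc([C@H]2CC[C@@H]3[C@@H](CCCCCOc4ccccc4)[C@H](O)C[C@@H]3O2)n1`, the saturated-chain counterpart, stands at "not determined" (no result reported) in this assay, so no number anchors this branch. Compound 3 `O=C(O)c1csc([C@H]2CC[C@@H]3[C@@H](CCOc4ccccc4)[C@H](O)C[C@@H]3O2)n1` is to be measured in this assay; it differs from compound 2 by phenoxy in place of 3-phenoxypropyl on a saturated chain carbon, two bonds along the chain from a saturated ring carbon. Within the data shown here, with only compound 1 as a reference and no step to lean on, the shortened chain of compound 3 is expected to move the read-out in this assay toward larger amounts, by more than the scatter. For compound 3 the expected value is 20000 nM, with a range from 3000 nM to 100000 nM.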

Compound 3, half-maximal effective concentration: > 10000 nM
Compound 3 ended at the assay's limit; the forecaster's own chance of this, stated with the estimate: 35%; the middle value lies beyond the limit too.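

No step can be read from compound 2 to compound 3 in this assay, as compound 2 has no number and compound 3 gives only a limit, > 10000 nM. The compounds shown leave open how 3-phenoxypropyl and phenoxy compare on the saturated chain.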